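Chloro in Place of Nitro: What Compound 4 Should Show

The source may hold more compounds than are shown below. What is called first, only, known or untested is meant among the compounds shown, and "the series" means these compounds.

Compound 1 `Clc1cccc(Cn2cc(COc3ccccc3)nn2)c1`: in an ADME assay on PANC-1 cells (Homo sapiens) for inhibition, read by MTT assay, with a stated time of 48 h (on this read-out higher numbers stand for weaker inhibition of growth and lower numbers for stronger inhibition of growth), compound 1 gives > 100 ug/mL, a limit of the assay.
Compound 2 `Cc1ccc(OCc2cn(Cc3cccc(Cl)c3)nn2)cc1`: in this assay compound 2 gives > 100 ug/mL, a limit of the assay.
Compound 3 `O=[N+]([O-])c1cccc(Cn2cc(COc3ccc(Cl)cc3)nn2)c1`: in this assay compound 3 gives > 100 ug/mL, a limit of the assay.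

Compound 3 stands where every measured compound stands, at the limit described by the limit of > 100 ug/mL in this assay, at which 3 of the 3 values shown sit, so no number is known for it. Within the data shown here, the one measured step, a step that the two limits leave unreadable from compound 1 to compound 2, has a limit at each end and gives no readable size. Compound 4 `Clc1ccc(OCc2cn(Cc3cccc(Cl)c3)nn2)cc1` differs from compound 3 by chloro in place of nitro on an aromatic carbon. Among the measured compounds shown here, no measured step bears on this change, and nothing measured here separates any compound from another. Compound 4 is therefore expected to remain at the same limit in this assay, with an expected step that the limit leaves unreadable from compound 3 to compound 4. The estimate for compound 4 is 120 ug/mL, with a range from 40 ug/mL to 400 ug/mL, and most likely the assay will again report only a limit.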

Compound 4, concentration for 50% growth inhibition: > 100 ug/mL
Compound 4 was reported as a limit; the forecaster's own chance of this, stated with the estimate: 80%; the middle value does not contradict the limit.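

No new step can be read among compound 1, compound 2, compound 3 and compound 4, since every comparison has a limit at each end: the limit of > 100 ug/mL in this assay, at which 4 of the 4 values shown sit.
The compounds shown leave open whether any of these changes alters growth inhibition in this assay at all, and by how much.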